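The source may hold more compounds than are shown below. What is called first, only, known or untested is meant among the compounds shown, and "the series" means these compounds.

Measured compounds:
- compound 1, `OC[C@H]1O[C@@H](n2cnc3c(NCc4ccccc4Br)ncnc32)[C@H](O)[C@@H]1O`: > 166000 nM
- compound 2, `OC[C@H]1O[C@@H](n2cnc3c(NCc4ccc(Br)cc4)ncnc32)[C@H](O)[C@@H]1O`: > 166000 nM
- compound 3, `OC[C@H]1O[C@@H](n2cnc3c(NCc4ccc(F)cc4Cl)ncnc32)[C@H](O)[C@@H]1O`: > 166000 nM

All three readings come from a functional assay on HOS cells (Homo sapiens) for antiproliferative activity, with a stated time of 72 h; on this read-out lower numbers stand for stronger inhibition and higher numbers for weaker inhibition. The reading for compound 1 is a limit of the assay, not a number. The same holds for compound 2, whose reading is also a limit. The reading for compound 3 is a limit as well. So compound 1 stands at the edge of what this assay can report, and no rank among the three can be drawn.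

The steps a step that the two limits leave unreadable from compound 1 to compound 2, a step that the two limits leave unreadable from compound 1 to compound 3 and a step that the two limits leave unreadable from compound 2 to compound 3 are all unreadable because of the limit of > 166000 nM in this assay, at which 3 of the 3 values shown sit. Swapping the halogen pattern on the benzyl group has therefore not yet produced a measurable number.

Compound 4, `OC[C@H]1O[C@@H](n2cnc3c(NCc4ccc(F)c(Cl)c4)ncnc32)[C@H](O)[C@@H]1O`, has not been measured. It differs from compound 1 as follows: 3-chloro-4-fluorophenyl in place of 2-bromophenyl on a saturated chain carbon bound to a nitrogen on an aromatic ring. Within the data shown here, no measured step bears on this change in a readable way, so no step beyond the scatter can be expected. Compound 4 is expected to give about 200000 nM, between 80000 nM and 500000 nM. The corresponding expected step is a step that the limit leaves unreadable from compound 1 to compound 4, most likely again only a limit.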

Compound 4, half-maximal inhibitory concentration: > 166000 nM
Compound 4: only a limit was reported (the forecaster's own chance of this, stated with the estimate: 85%); the middle value does not contradict the limit.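

Among these compounds, no step from compound 1, compound 2 or compound 3 to compound 4 can be read, because compound 4 also gives only a limit, not a number: the limit of > 166000 nM in this assay, at which 4 of the 4 values shown sit. The compounds shown leave open whether these four halogen patterns on the benzyl group differ at all in this assay.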